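Trading a Phenyl Ring for Pyridine in a Serotonin Receptor Ligand Series

The compounds below may be only part of what the source reports. "The series", "measured", "known", "first", "only" and "open" are said of these compounds alone.

Measured compounds:
compound 1, `CC(Nc1cc(N2CCN(C)CC2)ccc1[N+](=O)[O-])c1ccccc1`, 12 nM
compound 2, `O=[N+]([O-])c1ccc(N2CCNCC2)cc1NCc1ccccc1`, 28 nM
compound 3, `CN1CCN(c2ccc([N+](=O)[O-])c(NC(c3ccccc3)c3ccccc3)c2)CC1`, 4490 nM

Of the compounds shown here, three share one core and have been tested in an assay on HEK293 cells for displacement of a labelled ligand from 5-hydroxytryptamine receptor 6 (Homo sapiens); on this read-out higher numbers stand for weaker inhibition and lower numbers for stronger inhibition. Compound 1 gives 12 nM, the lowest number of the three and thus the strongest inhibition seen so far. Compound 2 gives 28 nM, a somewhat higher number. Compound 2 differs from compound 1 in two places at once, so nothing more than the two values can be read from that pair. For the measured compounds named here, compound 3 gives 4490 nM, and the only single-site step here, a 370-fold higher number from compound 1 to compound 3 (2.57 log units; beyond the scatter), shows that adding a second phenyl to the carbon that carries the amine and the first phenyl costs a great deal.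

The unmeasured compound 4, `CN1CCN(c2ccc([N+](=O)[O-])c(NCc3cccnc3)c2)CC1`, is made from compound 1 by the change ((pyridin-3-yl)methyl in place of 1-phenylethyl on a nitrogen on an aromatic ring). Going by the values given here, no measured step describes this change directly. The step from compound 1 to compound 3 concerns a different alteration, and compound 2 shows that a smaller group on that nitrogen still gives a low number. The change to compound 4 removes the methyl and brings a ring nitrogen in; without a matching measured step, a modest rise in the number is expected rather than a large one. For compound 4 in this assay a value of 40 nM is expected, within a range from 10 nM to 160 nM, corresponding to an estimated step of a 3.3-fold higher number from compound 1 to compound 4 (0.52 log units; beyond the scatter).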

Compound 4, inhibition constant: 1270 nM
The estimate for compound 4 lay 32-fold (1.50 log units) below the measured number; measured number outside the range, above it.
By their numbers in this assay, from the lowest: compound 1; then compound 2; then compound 4; then compound 3.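

On this assay, the step of a 110-fold higher number from compound 1 to compound 4 (2.02 log units; beyond the scatter) shows that a large rise in the number at this nitrogen does not require adding a phenyl, as in the step of a 370-fold higher number from compound 1 to compound 3 (2.57 log units; beyond the scatter). Here the entering (pyridin-3-yl)methyl has fewer heavy atoms than the 1-phenylethyl it replaces, yet the step is still large, so the group on a nitrogen on an aromatic ring matters for more than added size alone. No measurement is available that explains this rise.

The single step combines two differences, the loss of the methyl from the chain carbon and the appearance of a nitrogen in the ring, and the compounds shown cannot say how much of the rise belongs to each. A compound with 1-(pyridin-3-yl)ethyl on this nitrogen would keep the methyl while carrying the ring nitrogen, and its value would begin to separate the two differences.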